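The source may report more compounds than this note shows. Statements on the series, on what has been measured and on what is new or still open speak of the compounds shown alone.

In a functional assay on HCT-116 cells (Homo sapiens) for cytotoxicity, read by MTT assay, with a stated time of 72 h (a lower number here means a stronger inhibitor, a higher number a weaker inhibitor), compound 1 `Cc1cc(S(=O)(=O)/N=C(\N)n2nccc2-c2ccccc2)c(SCc2ccccc2Cl)cc1Cl` gives 18000 nM, the second highest of the three numbers. Compound 2 `Cc1cc(-c2ccccc2)n(/C(N)=N/S(=O)(=O)c2cc(C)c(Cl)cc2SCc2ccccc2C(F)(F)F)n1` gives 25000 nM in this assay, within the scatter of compound 1, while compound 3 `Cc1cc(-c2ccccc2)n(/C(N)=N/S(=O)(=O)c2cc(C)c(Cl)cc2SCc2cccc3ccccc23)n1` gives 7000 nM, the lowest of the three. Going by the values given here, the only single-place step, a 3.6-fold lower number from compound 2 to compound 3 (0.55 log units; beyond the scatter), touches the same place as the change leading to compound 4 `Cc1cc(S(=O)(=O)/N=C(\N)n2nccc2-c2ccccc2)c(SCc2cccc(Cl)c2)cc1Cl`, namely (3-chlorophenyl in place of 2-chlorophenyl on a saturated chain carbon bound to a sulfur), but it exchanges a different group, so it offers no direction for a chlorophenyl exchanged for another chlorophenyl. With no closer comparison, a step of a 1.2-fold lower number from compound 1 to compound 4 (0.08 log units; within the scatter) is expected, which may well fall within the scatter. Compound 4 is therefore estimated at 15000 nM, with a range from 6000 nM to 40000 nM.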

Compound 4, half-maximal inhibitory concentration: 7000 nM
For compound 4 the middle estimate is 2.1-fold (0.33 log units) above the measured one; measured number inside the range.
By their numbers in this assay, from the lowest: compounds 3 and 4 (each within the scatter of the next); then compounds 1 and 2 (each within the scatter of the next).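

In this assay, 3-chlorophenyl in place of 2-chlorophenyl on a saturated chain carbon bound to a sulfur gives a 2.6-fold lower number from compound 1 to compound 4 (0.41 log units; beyond the scatter). The earlier step at this place exchanged two different groups, whereas here the atoms stay the same, so the location of the chlorine alone changes the number beyond the scatter. Nothing available explains this step.

As far as these compounds go, whether a bromine or a methoxy group on this ring would follow the chlorine remains open. So does whether a longer chain in place of the benzyl would keep the lower number.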